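This account rests on a few compounds, and the source may have more. Where it says the series, first, only, none or still open, it means among the compounds named here.

Working notes on the series

Compound 1 `C/C=C/C=C/C(=O)N1CCN(c2nc(N)c3cc(OC)c(OC)cc3n2)CC1` is the reference point for the step under consideration. In an assay on cell membranes for displacement of a labelled ligand from Adrenergic receptor alpha-1 (Rattus norvegicus), tested at 100 nM (a lower number here means a stronger inhibitor, a higher number a weaker inhibitor), compound 1 gives 4.37 nM. For the measured compounds named here, the only other measured member, compound 2 `COc1ccc(/C=C/C(=O)N2CCN(c3nc(N)c4cc(OC)c(OC)cc4n3)CC2)cc1`, gives 3.39 nM in this assay. Within this pair compound 1 carries the higher of the two numbers, and the step of a 1.3-fold lower number from compound 1 to compound 2 (0.11 log units; within the scatter) places compound 2 within the scatter of compound 1, so the two cannot be told apart on these data.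

Compound 3 `COc1cc2nc(N3CCN(C(=O)/C=C/c4ccc(NC(=O)CBr)cc4)CC3)nc(N)c2cc1OC` is not yet measured. It differs from compound 1 by 4-(((bromomethyl)carbonyl)amino)phenyl in place of prop-1-en-1-yl on a double-bonded chain carbon bound to a double-bonded chain carbon. Going by the values given here, the one measured step that bears on this change is the move from compound 1 to compound 2, in which an aryl group took the same place on the chain: a 1.3-fold lower number from compound 1 to compound 2 (0.11 log units; within the scatter). That exchange left the number essentially unchanged. An aryl group entering at the same position in compound 3 is therefore expected to give no step beyond the scatter, with at most a slight drift toward a lower number, as a 1.2-fold lower number from compound 1 to compound 3 (0.10 log units; within the scatter).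

For compound 3 the expected value in this assay is 3.5 nM, with a plausible range of 1.2 nM to 10 nM.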

Compound 3, half-maximal inhibitory concentration: 67.6 nM
Estimate against measurement, compound 3: 19-fold (1.29 log units) below; measured number above the stated range.
By their numbers in this assay, from the lowest: compounds 2 and 1 (each within the scatter of the next); then compound 3.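

In this assay this place on the chain does not accept every aryl group alike: the step reads a 15-fold higher number from compound 1 to compound 3 (1.19 log units; beyond the scatter), whereas the 4-methoxyphenyl group of compound 2 had stayed within the scatter of compound 1. The closer comparison lies on the aromatic carbon, where ((bromomethyl)carbonyl)amino in place of methoxy gives a 20-fold higher number from compound 2 to compound 3 (1.30 log units; beyond the scatter), so the rise in the number follows the change of substituent on the ring and not the entry of an aryl group alone. Nothing on hand speaks to the origin of this step.

The compounds shown leave open whether the rise belongs to the bromine or to the amide that carries it, a question that a plain acetylamino group or a simple amine on the same aromatic carbon would help to separate. Also open, on these data alone, is how far the number moves with other groups in that place, such as a hydroxyl group, a carboxylic acid or a longer acylamino chain.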